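The source may report more compounds than this note shows. Statements on the series, on what has been measured and on what is new or still open speak of the compounds shown alone.

Measured in a functional assay on the whole organism (strain Sprague-Dawley) for inhibition, with Rattus norvegicus as the target, with a stated time of 10 min; a lower number here means that less compound is needed, a higher number that more compound is needed for the effect:

- Compound 1 `CSc1ccccc1-c1ncc(C(=O)O)c(=O)[nH]1`: > 20 mg/kg (a limit of the assay)
- Compound 2 `CCOC(=O)c1cnc(-c2ccccc2[N+](=O)[O-])[nH]c1=O`: "not determined" (no result reported)
- Compound 3 `CCOC(=O)c1cnc(-c2ccccc2OCC(C)C)[nH]c1=O`: 3 mg/kg

For the measured compounds named here, compound 3 gives the only actual number in this small set, 3 mg/kg. Compound 1 reaches only a limit, > 20 mg/kg. Going by the values given here, compound 2 has no result to compare, so there is no measured step to serve as a guide.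

Compound 4 `CCOC(=O)c1cnc(-c2ccccc2SC)[nH]c1=O` keeps the ester and shared core of compound 3 but has methylsulfanyl in place of isobutoxy on an aromatic carbon, ortho to a large group (methylsulfanyl in place of isobutoxy on an aromatic carbon). The change swaps a longer branched group for a much smaller one, and nothing measured here shows what such a swap does. Among the compounds with values here, the only anchor is compound 3 at 3 mg/kg, so a moderate loss seems the more likely outcome, though a result within the usual scatter would not be surprising. The expected change is a 2.7-fold higher number from compound 3 to compound 4 (0.43 log units; beyond the scatter), towards a higher dose. For compound 4 the estimated dose is 8 mg/kg, with an expected range of 2 mg/kg to 30 mg/kg.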

Compound 4, dose for 50% inhibition: > 25 mg/kg
Compound 4 was reported as a limit; the forecaster's own chance of this, stated with the estimate: 30%; middle value at least 3.1-fold (0.49 log units) from the limit.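

In this assay, for the compounds shown here, this is the first readable step at this position, on an aromatic carbon ortho to a large group, and methylsulfanyl in place of isobutoxy gives an at least 8.3-fold higher number from compound 3 to compound 4 (0.92 log units; beyond the scatter). With the ester and the shared core unchanged, this shows that the group at this position strongly affects the dose needed, and that methylsulfanyl does not preserve the result seen with isobutoxy. Compound 4 reaches only a limit, so the full size of the loss remains unknown: the limit of > 25 mg/kg in this assay, at which 1 of the 4 values shown sits.

The step between compound 1 and compound 4 joins two limits and cannot be read. Also open, on these data alone, is whether a methoxy group, a longer chain such as hexyloxy, or an amine at this position would match compound 3.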